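This account rests on a few compounds, and the source may have more. Where it says the series, first, only, none or still open, it means among the compounds named here.

Compound 1 `O=C(O)CCc1ccc(OCC2COc3ccc(Cl)cc3O2)cc1F` gives 830 nM in a functional assay on HEK293 cells for agonist activity at Free fatty acid receptor 1 (Homo sapiens), read by fluorescence and calcium flux, with a stated time of 10 min; on this read-out higher numbers stand for an effect only at larger amounts of compound and lower numbers for an effect already at smaller amounts.
Compound 2 `O=C(O)CCc1ccc(OCC2COc3ccc(Br)cc3O2)cc1F` gives 2240 nM in this assay.
Compound 3 `CC#C[C@@H](CC(=O)O)c1ccc(OC[C@H]2COc3cc(Cl)c(Cl)cc3O2)cc1` gives 150 nM in this assay.

The first two compounds share a core and differ at one spot: bromo in place of chloro on an aromatic carbon. On that change the number rises, a 2.7-fold higher number from compound 1 to compound 2 (0.43 log units; beyond the scatter), so compound 2 acts only at larger amounts than compound 1. Compound 3 rests on a different core; how it differs from compound 1 is not broken down here. Of the three measured compounds, compound 3 has the lowest number, and its gaps to compound 1 and to compound 2 both lie beyond the usual scatter.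

Compound 4 `CC#C[C@@H](CC(=O)O)c1ccc(OC[C@H]2COc3cc(Br)c(Cl)cc3O2)cc1` is not yet measured. It is derived from compound 3 by bromo in place of chloro on an aromatic carbon. The spot sits ortho to a chloro group, which is not so for the change from compound 1 to compound 2, so the two are the same kind of change rather than the same change. For the measured compounds named here, the only guide from compound 1 to compound 2 is a 2.7-fold higher number from compound 1 to compound 2 (0.43 log units; beyond the scatter), and compound 4 is expected to follow it in direction, with a step estimated as a 2.5-fold higher number from compound 3 to compound 4 (0.40 log units; beyond the scatter) in this assay, because a 2.7-fold higher number from compound 1 to compound 2 (0.43 log units; beyond the scatter) points to a modest rise. Compound 4 is thus expected to give 380 nM in this assay, with an estimated span from 180 nM to 900 nM.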

Compound 4, half-maximal effective concentration: 200 nM
Compound 4: the middle estimate sits 1.9-fold (0.28 log units) above what was measured, and the stated range covers the measured number.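

On the second core, bromo in place of chloro gives a 1.3-fold higher number from compound 3 to compound 4 (0.12 log units; within the scatter) in this assay, so this pair cannot be told apart on this read-out. Set beside the earlier step, the change does not differ measurably between the two cores: the same change on two cores in this assay, a 2.7-fold higher number (0.43 log units; beyond the scatter) from compound 1 to compound 2 and a 1.3-fold higher number (0.12 log units; within the scatter) from compound 3 to compound 4, 2.0-fold (0.31 log units) apart, within the scatter of two such steps. The step lies beyond the scatter on one core and within it on the other, and two pairs show neither that the change carries a fixed size from core to core nor whether its place, ortho to a chloro group on the second core only, has any bearing on its size.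

The compounds shown leave open how a nitrile, a methoxy group or a trifluoromethyl group would fare at this spot on either core, since chloro and bromo are the only groups shown there. They also leave open whether the same swap at the remaining chloro group of compound 3 would give a similar result, and whether the step would hold on a core carrying an amide or a tetrazole in place of the carboxylic acid.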